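Amide-to-urea step on the chloro-trifluoromethylphenyl tail

The compounds below may be only part of what the source reports. "The series", "measured", "known", "first", "only" and "open" are said of these compounds alone.

Measured so far:
compound 1 `COc1cc(-c2nn(-c3cccc(NC(=O)Nc4ccc(Cl)c(Cl)c4)c3)cc2-c2ccncc2)ccc1Cl`: 1140 nM
compound 2 `COc1cc(-c2nn(-c3cccc(NC(=O)c4ccc(Cl)c(C(F)(F)F)c4)c3)cc2-c2ccncc2)ccc1Cl`: 2700 nM

In a functional assay on A498 cells (Homo sapiens) for inhibition, read by sulforhodamine B assay, with a stated time of 48 h (on this read-out higher numbers stand for weaker inhibition of growth and lower numbers for stronger inhibition of growth), compound 2 gives the higher of the two numbers; its nearest neighbour is compound 1, and the step between them is a 2.4-fold higher number from compound 1 to compound 2 (0.37 log units; beyond the scatter). Compound 3 `COc1cc(-c2nn(-c3cccc(NC(=O)Nc4ccc(Cl)c(C(F)(F)F)c4)c3)cc2-c2ccncc2)ccc1Cl` differs from compound 2 by (4-chloro-3-(trifluoromethyl)phenyl)amino in place of 4-chloro-3-(trifluoromethyl)phenyl on a carbonyl carbon. For the measured compounds named here, only one measured step bears on this, a 2.4-fold higher number from compound 1 to compound 2 (0.37 log units; beyond the scatter), and it altered the tail ring substituents as well as the linker, so it is an imperfect guide. Returning to the urea is expected to bring the number back toward that of compound 1, an expected step of a 2.1-fold lower number from compound 2 to compound 3 (0.32 log units; beyond the scatter). The estimate for compound 3 is therefore 1300 nM, within 500 nM to 3500 nM.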

Compound 3, concentration for 50% growth inhibition: 837 nM
Estimate against measurement, compound 3: 1.6-fold (0.19 log units) above; the measured number falls inside the stated range.
By their numbers in this assay, from the lowest: compounds 3 and 1 (each within the scatter of the next); then compound 2.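

With the tail ring held constant, (4-chloro-3-(trifluoromethyl)phenyl)amino in place of 4-chloro-3-(trifluoromethyl)phenyl on the carbonyl carbon gives a 3.2-fold lower number from compound 2 to compound 3 (0.51 log units; beyond the scatter) in this assay and isolates the urea-versus-amide change, which the earlier step mixed with a ring change. Within the urea pair, trifluoromethyl in place of chloro gives a 1.4-fold lower number from compound 1 to compound 3 (0.13 log units; within the scatter) so this ring change does not separate the two ureas.

From the compounds shown here alone, how a thiourea or a sulfonamide linker would read on this tail remains open. The reason for the urea-amide difference also remains open, as no supporting data accompany these results.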